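Isopropyl in place of methoxy: compound 1 to compound 3

The source may hold more compounds than are shown below. What is called first, only, known or untested is meant among the compounds shown, and "the series" means these compounds.

Compound 1 `COc1ccc([N+](=O)[O-])cc1S(=O)(=O)N(C)/N=C/c1cnn2ccc(C#N)cc12` is the anchor of this pair. Among the measured compounds shown here, in an assay on isolated protein for inhibition of phosphatidylinositol 4,5-bisphosphate 3-kinase catalytic subunit beta isoform (Homo sapiens), read by 33P incorporation, with a stated time of 60 min (a lower number here means a stronger inhibitor, a higher number a weaker inhibitor), compound 1 gives 63 nM, the only outright number in the set so far. Compound 2 `Cc1ccccc1S(=O)(=O)N(C)/N=C/c1cnn2ccc(C#N)cc12` is the other measured member. In this assay compound 2 gives > 1000 nM, which is a limit of the assay rather than a number (the limit of > 1000 nM in this assay, at which 1 of the 2 values shown sits). For the measured compounds named here, no single-change step between measured compounds exists here, so the two values say only that compound 1 is the one with a number and compound 2 sits at the limit; compound 2 differs from compound 1 in more than one place and no difference between them is counted.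

Compound 3 `CC(C)c1ccc([N+](=O)[O-])cc1S(=O)(=O)N(C)/N=C/c1cnn2ccc(C#N)cc12` is not yet measured. It differs from compound 1 in one place: isopropyl in place of methoxy on an aromatic carbon. Going by the values given here, with no measured step of this kind to lean on, the expected step from compound 1 to compound 3 in this assay is a 2.4-fold higher number from compound 1 to compound 3 (0.38 log units; beyond the scatter), a modest weakening that may not clear the scatter. Compound 3 is estimated at 150 nM in this assay, within 40 nM to 600 nM.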

Compound 3, half-maximal inhibitory concentration: 300 nM
Compound 3: middle estimate off by 2.0-fold (0.30 log units), on the low side; low and high end bracket the measured number.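

In this assay, among the compounds shown here, the step at this position, a 4.8-fold higher number from compound 1 to compound 3 (0.68 log units; beyond the scatter), is the first single-change comparison. It shows that the aromatic carbon ortho to a large group and para to a nitro group responds to the choice of substituent, and that isopropyl in place of methoxy costs potency while still giving a measured number rather than a limit of the assay. Methoxy is counted with a hydrogen-bond acceptor and isopropyl with none, but they also differ in heavy atoms and composition, and nothing shown ties the step to any one of these differences.

As far as these compounds go, with one step at this position, no trend across substituents can be drawn, and it remains open how an ethoxy group, a hydroxyl, a chlorine or a dimethylamino group would read here in this assay. Also open, from the compounds shown here alone, is whether this step keeps its size when the nitro group is exchanged for an amine or a nitrile on the same ring.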